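Removing the pentyl from the selenium of compound 3

The compounds below may be only part of what the source reports. "The series", "measured", "known", "first", "only" and "open" are said of these compounds alone.

Measured compounds:
- compound 1, `CCCCC[Se]c1nc([Se]CCCCC)c2cccnc2n1`: 15200 nM
- compound 2, `COc1ccc(CNc2nc([SeH])nc3ccccc23)cc1`: 7110 nM
- compound 3, `CCCCC[Se]c1nc(NCc2ccc(SC)cc2)c2ccccc2n1`: 40400 nM

In a functional assay on HTB-54 cells (Homo sapiens) for cytotoxicity, read by MTT assay, with a stated time of 72 h (on this read-out higher numbers stand for weaker inhibition of growth and lower numbers for stronger inhibition of growth), compound 3 gives the highest of the three numbers. Compound 1 sits nearest to it, and its number is lower by a margin beyond the scatter; compound 2 lies furthest away, with a number lower by a margin that is also beyond the scatter. Compound 3 is thus the weakest of the three on this read-out.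

Compound 4, `CSc1ccc(CNc2nc([SeH])nc3ccccc23)cc1`, is the unmeasured neighbour of compound 3. The change is hydrogen in place of pentyl on a selenium. For the measured compounds named here, no measured pair shows this single change. Compound 2, however, also carries hydrogen on its selenium and differs from compound 4 only in the group on the benzyl ring; in this assay compound 2 gives 7110 nM. On that basis the step from compound 3 to compound 4 is expected to be a decrease, estimated as a 4.5-fold lower number from compound 3 to compound 4 (0.65 log units; beyond the scatter), beyond the scatter. Compound 4 is therefore expected to give about 9000 nM, in a range from 3000 nM to 30000 nM.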

Compound 4, concentration for 50% growth inhibition: 45500 nM
The estimate for compound 4 lay 5.1-fold (0.70 log units) below the measured number, outside the stated range (above it).
By their numbers in this assay, from the lowest: compound 2; then compound 1; then compounds 3 and 4 (each within the scatter of the next).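

In this assay, hydrogen in place of pentyl on a selenium gives a 1.1-fold higher number from compound 3 to compound 4 (0.05 log units; within the scatter), so with methylsulfanyl on the aromatic carbon, this selenium position gives no sign of depending on the pentyl. For the compounds shown here, the group on the aromatic carbon behaves differently: with hydrogen on the selenium in both compounds, methylsulfanyl in place of methoxy gives a 6.4-fold higher number from compound 2 to compound 4 (0.81 log units; beyond the scatter), a step beyond the scatter and the larger of the two single changes now readable, neither of which the earlier compounds could isolate. Nothing measured here accounts for either step.

The compounds shown do not tell whether pentyl and hydrogen on the selenium would also read alike with methoxy on the aromatic carbon, as the pentyl partner of compound 2 is not among them. They also leave open how a shorter chain such as methyl or a benzyl group would read on the selenium, and how a hydroxyl group or a chlorine atom would read in place of methoxy or methylsulfanyl on the aromatic carbon.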